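The source may hold more compounds than are shown below. What is called first, only, known or untested is meant among the compounds shown, and "the series" means these compounds.

Three compounds have been measured in an assay for inhibition of acyl-CoA:cholesterol acyltransferase (Oryctolagus cuniculus), using microsomes; a higher number here means a weaker inhibitor, a lower number a stronger inhibitor:
compound 1 `CCCCCCCCC(C)(C)C(=O)Nc1c(C)cc(C)c2c1OC(C)(C)C2` gives 140 nM;
compound 2 `Cc1cc(C)c(NC(=O)C(C)(C)CCCOc2ccc(Cl)cc2)c2c1CC(C)(C)O2` gives 260 nM;
compound 3 `Cc1cc(C)c(NC(=O)C(C)(C)CCCCCCOc2ccc(Cl)cc2)c2c1CC(C)(C)O2` gives 76 nM.

Among these three numbers compound 1 stands second highest. Its nearest neighbour is reached by a 1.8-fold lower number from compound 1 to compound 3 (0.27 log units; within the scatter) and its furthest by a 1.9-fold higher number from compound 1 to compound 2 (0.27 log units; within the scatter); both steps stay within the scatter, so compound 1 cannot be separated from either on the numbers shown. Going by the values given here, the one step that does pass the scatter is a 3.4-fold lower number from compound 2 to compound 3 (0.53 log units; beyond the scatter).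

Compound 4 `Cc1ccc(OCCCCCCC(C)(C)C(=O)Nc2c(C)cc(C)c3c2OC(C)(C)C3)cc1` differs from compound 1 in one place: 4-methylphenoxy in place of ethyl on a saturated chain carbon, seven bonds along the chain from a carbonyl carbon. Among the compounds with values here, the closest precedent is the step in which a 4-chlorophenoxy entered at the same saturated chain carbon, seven bonds along the chain from a carbonyl carbon, giving a 1.8-fold lower number from compound 1 to compound 3 (0.27 log units; within the scatter). The other change of this kind, a 4-chlorophenoxy four bonds along the chain from a carbonyl carbon, gave a 1.9-fold higher number from compound 1 to compound 2 (0.27 log units; within the scatter). Neither moved the number beyond the scatter. A 4-methylphenoxy in the position where the 4-chlorophenoxy sat is therefore expected to behave much as compound 3 did, with a small downward step that need not pass the scatter. Compound 4 is expected at 100 nM in this assay, between 45 nM and 230 nM, which amounts to a 1.4-fold lower number from compound 1 to compound 4 (0.15 log units; within the scatter).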

Compound 4, half-maximal inhibitory concentration: 50 nM
Estimate against measurement, compound 4: 2.0-fold (0.30 log units) above, within the range that was stated.
By their numbers in this assay, from the lowest: compounds 4, 3, 1 and 2 (each within the scatter of the next, the first and the last beyond it).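

In this assay, 4-methylphenoxy on the saturated chain carbon seven bonds along the chain from a carbonyl carbon gives the first step from compound 1 at this position to pass the scatter (a 2.8-fold lower number from compound 1 to compound 4 (0.45 log units; beyond the scatter)), which the 4-chlorophenoxy in the same place did not do. Methyl in place of chloro on an aromatic carbon stays within the scatter (a 1.5-fold lower number from compound 3 to compound 4 (0.18 log units; within the scatter)), so the change of ring substituent cannot be told apart on these numbers, and the gain over compound 1 cannot be credited to methyl rather than chloro. The step that moves the group from four to seven bonds along the chain while also exchanging chloro for methyl is the largest in the set (a 5.2-fold lower number from compound 2 to compound 4 (0.72 log units; beyond the scatter)), and nothing available accounts for any of these steps.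

The compounds shown leave open how a 4-methylphenoxy would behave four bonds along the chain from a carbonyl carbon, and so whether it would follow the 4-chlorophenoxy of compound 2. They also leave open what an unsubstituted phenoxy, a carboxylic acid or an amine would do on the same saturated chain carbon, or what a longer chain would do.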